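The compounds below may be only part of what the source reports. "The series", "measured", "known", "first", "only" and "open" are said of these compounds alone.

Measured so far in a physicochemical assay for lipophilicity, at pH 7.4; a higher number here means a more lipophilic compound, a lower number a more polar compound:
- compound 1 `CNC(=O)c1cc(C(=O)N[C@H]2[C@@H]3COC[C@@H]32)cc2c1OC[C@H]2c1cccc(OC)c1` gives 3.2
- compound 2 `CNC(=O)c1cc(C(=O)N[C@H]2[C@@H]3COC[C@@H]32)cc2c1OC[C@@]2(CO)c1ccccc1` gives 2.4
- compound 3 `CNC(=O)c1cc(C(=O)N[C@H]2[C@@H]3COC[C@@H]32)cc2c1OC[C@H]2c1ccccc1` gives 3.3

Compound 2 is the lowest of the three, and compound 1 and compound 3 both stand beyond the scatter above it.

Compound 4 `CC[C@@]1(c2ccccc2)COc2c(C(=O)NC)cc(C(=O)N[C@H]3[C@@H]4COC[C@@H]43)cc21` differs from compound 2 by a single change, hydroxymethyl to ethyl: methyl in place of hydroxy on a saturated chain carbon bound to a saturated ring carbon in the form of methyl in place of hydroxy on a saturated chain carbon bound to a saturated ring carbon.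

For the measured compounds named here, the one measured step, a number 0.10 log units higher from compound 1 to compound 3 (within the scatter) with hydrogen in place of methoxy on an aromatic carbon, stays within the scatter and involves neither hydroxy nor methyl, so it bears only weakly on this change. Going by the values given here, no measured step exchanges hydroxy for methyl. The nearest guide is therefore a level, compound 3 at 3.3 in this assay as the top of the set.

An upward move beyond the scatter is expected, with the estimated step of a number 1.30 log units higher from compound 2 to compound 4 (beyond the scatter) as the working figure. For compound 4 the expected value is 3.7 within an estimated range of 3.3 to 4.1 for now.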

Compound 4, distribution coefficient: 4.2
For compound 4 the middle estimate is 0.50 log units below the measured one; measured number outside the range, above it.
By their numbers in this assay, from the lowest: compound 2; then compounds 1 and 3 (each within the scatter of the next); then compound 4.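

In this assay, for the compounds shown here, the exchange of hydroxy for methyl on a saturated chain carbon bound to a saturated ring carbon gives (a number 1.80 log units higher from compound 2 to compound 4 (beyond the scatter)), so this place moves the number far more than the one earlier step on an aromatic carbon. Compound 3, which carries hydrogen on the ring carbon that holds the hydroxymethyl or ethyl group in the other two, stands at (3.3), between compound 2 (2.4) and compound 4 (4.2), so hydroxymethyl and ethyl fall on opposite sides of hydrogen here. Nothing available accounts for the size of this step.

Still open is where a methoxymethyl group, an aminomethyl group or a longer chain such as propyl would fall on this carbon in this assay among these three. Also open, going by these compounds, is whether the step from hydroxymethyl to ethyl keeps its size when the phenyl group carries methoxy, as in compound 1.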